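Working notes: replacing the amine on compound 3

This account rests on a few compounds, and the source may have more. Where it says the series, first, only, none or still open, it means among the compounds named here.

Measured compounds:
compound 1 `Cc1ccc(CNC(=O)c2cccc(C(C)Oc3ccnc(Nc4cnn(C5CCN(C)CC5)c4)c3)c2)cc1`: 8900 nM
compound 2 `Cc1ccc(CNC(=O)c2cccc(C(C)Oc3ccnc(NN4CCOCC4)c3)c2)cc1`: > 100000 nM (a limit of the assay)
compound 3 `Cc1ccc(CNC(=O)c2cccc(C(C)Oc3ccnc(NN4CCN(C)CC4)c3)c2)cc1`: 8100 nM

In a functional assay on NCI-H3122 cells (Homo sapiens) for antiproliferative activity, read by MTT assay, with a stated time of 48 h (a lower number here means a stronger inhibitor, a higher number a weaker inhibitor), compound 1 gives 8900 nM and compound 3 gives 8100 nM. For compound 2 the value > 100000 nM is a limit of the assay, not a number. Compound 3 holds the lowest of the two numbers shown, but a 1.1-fold lower number from compound 1 to compound 3 (0.04 log units; within the scatter), so compound 1 and compound 3 cannot be ordered. The two steps through compound 2 are large: an at least 11-fold higher number from compound 1 to compound 2 (1.05 log units; beyond the scatter) and an at least 12-fold lower number from compound 2 to compound 3 (1.09 log units; beyond the scatter).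

Compound 4 `Cc1ccc(CNC(=O)c2cccc(C(C)Oc3ccnc(Nc4nc5ccccc5[nH]4)c3)c2)cc1` differs from compound 3 in one place: 1H-benzimidazol-2-yl in place of 4-methylpiperazin-1-yl on a nitrogen on an aromatic ring. Compound 1 carries an aromatic ring at the same nitrogen and a 1.1-fold lower number from compound 1 to compound 3 (0.04 log units; within the scatter), which points to little change; compound 2 shows that a step beyond the scatter is possible at this position. Compound 4 is expected near 7500 nM, range 2000 nM to 30000 nM. The expected step is a 1.1-fold lower number from compound 3 to compound 4 (0.03 log units; within the scatter).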

Compound 4, half-maximal inhibitory concentration: 9400 nM
For compound 4 the middle estimate is 1.3-fold (0.10 log units) below the measured one, within the range that was stated.
By their numbers in this assay, from the lowest: compounds 3, 1 and 4 (each within the scatter of the next). At a limit, above all of these: compound 2.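

With 1H-benzimidazol-2-yl on this nitrogen, the number stays level with both 4-methylpiperazin-1-yl (a 1.2-fold higher number from compound 3 to compound 4 (0.06 log units; within the scatter)) and 1-(1-methylpiperidin-4-yl)-1H-pyrazol-4-yl (a 1.1-fold higher number from compound 1 to compound 4 (0.02 log units; within the scatter)). A fully aromatic group thus matches the non-aromatic 4-methylpiperazin-1-yl here, and only morpholin-4-yl stands apart (an at least 10-fold lower number from compound 2 to compound 4 (1.02 log units; beyond the scatter)). Compound 2 gives a limit, not a number: (the limit of > 100000 nM in this assay, at which 1 of the 4 values shown sits).

Going by these compounds, compounds 1, 3 and 4 cannot be ordered, so what would give a clearly stronger inhibitor at this position remains open. Whether a plain phenyl, a carboxylic acid or a simple primary amine on this nitrogen would stay level with them cannot be told from these compounds.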